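The source may report more compounds than this note shows. Statements on the series, on what has been measured and on what is new or still open speak of the compounds shown alone.

Compound 1 `CCOC(=O)c1ccc(/N=N/N(C)C(=O)NCCSc2ccc(O)cc2)cc1`: > 240 h
Compound 2 `Cc1ccc(/N=N/N(C)C(=O)CCc2ccc(O)cc2)cc1`: 101 h

For the measured compounds named here, in a physicochemical assay for pharmacokinetics, read by HPLC, in phosphate buffer, at pH 7.4 (on this read-out higher numbers stand for a longer-lived compound and lower numbers for a shorter-lived compound), compound 2 supplies the only actual number among the two values shown. For compound 1 the read-out is not a number but (the limit of > 240 h in this assay, at which 1 of the 2 values shown sits). Compound 3 `CC(=O)c1ccc(/N=N/N(C)C(=O)CCc2ccc(O)cc2)cc1` differs from compound 2 in one place only, (acetyl in place of methyl on an aromatic carbon), that is, acetyl in place of methyl on an aromatic carbon. Going by the values given here, no measured pair shows this particular change, so its size cannot be read from the data. Compound 1, which differs from compound 2 at more than one place, is the only pointer toward a longer-lived compound, and it sits at the limit of > 240 h in this assay, at which 1 of the 2 values shown sits. On that slim basis the step from compound 2 to compound 3 is expected to be modest and toward a longer half-life, a 1.8-fold higher number from compound 2 to compound 3 (0.25 log units; within the scatter), rather than flat or downward. Compound 3 is therefore estimated at 180 h, with a range from 80 h to 400 h.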

Compound 3, half-life: 139 h
The estimate for compound 3 lay 1.3-fold (0.11 log units) above the measured number; the range from low to high includes it.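

In this assay, the place on an aromatic carbon, para to a large group, now has its first measured step, as acetyl in place of methyl gives a 1.4-fold higher number from compound 2 to compound 3 (0.14 log units; within the scatter). Here a hydrogen-bond acceptor and a double bond outside aromatic rings enter with the acetyl, and the half-life stays within the usual scatter of repeated measurements, so this change has no effect that can be told apart from that scatter. Nothing in the data bears on why the two compounds read so closely.

Going by these compounds, whether an amine, a carboxylic acid or a longer chain at this same place would shift the half-life beyond the scatter remains open. On these data alone, compound 1 differs from compound 2 at more than one place, so what each of its differences contributes also stays open.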